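A few compounds are considered here, and "the series" means these few. Any claim that something is new, unique, unknown or untested is made for them only; others in the source may bear on it.

Working notes on the series, all read in a functional assay on MDA-MB-231 cells (Homo sapiens) for cytotoxicity, read by MTT assay, with a stated time of 48 h; a lower number here means a stronger inhibitor, a higher number a weaker inhibitor. The shared core is carried by compound 1 `Cc1ccc(S(=O)(=O)OCCCc2cn(-c3ccc(C(F)(F)F)cc3)nn2)cc1`, compound 2 `COc1ccc(-n2cc(CCCOS(=O)(=O)c3ccc(C)cc3)nn2)cc1` and compound 3 `Cc1ccc(S(=O)(=O)OCCCc2cn(-c3cccc(C#N)c3)nn2)cc1`. Compound 1 gives > 100000 nM, which is a limit and not a number. Within the data shown here, compound 2 gives 72800 nM, the only true number so far. Compound 3 gives > 100000 nM, again a limit and not a number. Compound 3 therefore stands at the limit of > 100000 nM in this assay, at which 2 of the 3 values shown sit.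

The next entry is compound 4 `Cc1ccc(-n2cc(CCCOS(=O)(=O)c3ccc(C)cc3)nn2)cc1`, which changes one place: 4-methylphenyl in place of 3-cyanophenyl on an aromatic nitrogen. In words, 4-methylphenyl comes in place of 3-cyanophenyl on an aromatic nitrogen.

Among the measured compounds shown here, two measured steps bear on this change, both at the same aromatic group of the series: an at least 1.3-fold lower number from compound 1 to compound 2 (0.13 log units; that floor lies within the scatter) and an at least 1.3-fold higher number from compound 2 to compound 3 (0.13 log units; that floor lies within the scatter). Neither has a floor beyond the scatter, so no large step is expected in this assay, and any movement should be small and towards a lower number. For the measured compounds named here, that direction leans on compound 2 at 72800 nM, whose 4-methoxyphenyl is the one group so far to give a number. The expected size is an at least 1.2-fold lower number from compound 3 to compound 4 (0.09 log units; that floor lies within the scatter). Compound 4 is estimated at 80000 nM, with an expected range of 40000 nM to 160000 nM.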

Compound 4, half-maximal inhibitory concentration: 36600 nM
The estimate for compound 4 lay 2.2-fold (0.34 log units) above the measured number, and the stated range ends above it.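

In this assay, among these compounds, 4-methylphenyl on the aromatic nitrogen gives the first steps that clear the scatter, with an at least 2.7-fold lower number from compound 3 to compound 4 (0.43 log units; beyond the scatter) and an at least 2.7-fold lower number from compound 1 to compound 4 (0.43 log units; beyond the scatter). The 4-methoxyphenyl group is not separated from it, however: methyl in place of methoxy gives a 2.0-fold lower number from compound 2 to compound 4 (0.30 log units; within the scatter), so these two groups cannot be ordered from the present data, and both stand apart from the groups that give only a limit. Going by these compounds, the two steps beyond the scatter start from limits and not from numbers, so each gives only a floor and its full size stays unknown: the limit of > 100000 nM in this assay, at which 2 of the 4 values shown sit.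

The step from 3-cyanophenyl to 4-methylphenyl alters both the group and where it sits on the phenyl ring, so a 4-cyanophenyl or a 3-methylphenyl would be needed to tell those two changes apart. Also open, on these data alone, is how an unsubstituted phenyl, a 4-aminophenyl or a 4-carboxyphenyl would read on the same aromatic nitrogen, and whether a longer chain within the shared core would move the number at all.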